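Trifluoromethyl in place of fluoro: compound 3 to compound 4

The source may hold more compounds than are shown below. What is called first, only, known or untested is meant among the compounds shown, and "the series" means these compounds.

In a functional assay on DU-145 cells (Homo sapiens) for inhibition, read by trypan blue exclusion, with a stated time of 96 h (on this read-out higher numbers stand for weaker inhibition of growth and lower numbers for stronger inhibition of growth), compound 1 `O=C(/C(=C\c1ccc(F)cc1C(F)(F)F)SCc1ccc(F)cc1)c1ccc(Br)cc1` gives 10000 nM and compound 2 `Cc1ccc(S/C(=C/c2ccc(Cl)cc2)C(=O)c2ccc(Br)cc2)cc1` gives 10000 nM. Compound 3 `Cc1ccc(S/C(=C/c2ccc(F)cc2F)C(=O)c2ccc(Br)cc2)cc1` reads > 100000 nM, which is a limit of the assay and not a number.

Compound 4 `Cc1ccc(S/C(=C/c2ccc(F)cc2C(F)(F)F)C(=O)c2ccc(Br)cc2)cc1` differs from compound 3 in one group: trifluoromethyl in place of fluoro on an aromatic carbon. The change is trifluoromethyl in place of fluoro on an aromatic carbon, ortho to a large group.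

Among the measured compounds shown here, one measured step bears on this: an at least 10-fold higher number from compound 2 to compound 3 (1.00 log units; beyond the scatter). It is only a bound, but it shows that a change on this aromatic group alone can move the number well beyond the scatter. Compound 4 carries the same substituted aromatic group as compound 1, and compound 1 gives 10000 nM, though the two differ elsewhere. A clear move towards stronger inhibition of growth is therefore expected, with some chance that the reading stays at the limit.

The expected change is an at least 6.6-fold lower number from compound 3 to compound 4 (0.82 log units; beyond the scatter). For compound 4 the estimate is 15000 nM, with an expected range of 4000 nM to 80000 nM.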

Compound 4, concentration for 50% growth inhibition: 25000 nM
Compound 4: the middle estimate sits 1.7-fold (0.22 log units) below what was measured; the measured number falls inside the stated range.
By their numbers in this assay, from the lowest: compounds 1 and 2 (each within the scatter of the next); then compound 4. At a limit, above all of these: compound 3.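

In this assay, trifluoromethyl in place of fluoro on this aromatic carbon, ortho to a large group, gives an at least 4.0-fold lower number from compound 3 to compound 4 (0.60 log units; beyond the scatter), so this single position can take the series from the limit to a measured number. Compound 3 stands at a limit, so this step is a bound and its full size is not known: the limit of > 100000 nM in this assay, at which 1 of the 4 values shown sits. With this aromatic group held constant, 4-methylphenyl in place of 4-fluorobenzyl on the sulfur gives a 2.5-fold higher number from compound 1 to compound 4 (0.40 log units; beyond the scatter), so the sulfur substituent also moves the number beyond the scatter, though by a modest step.

From the compounds shown here alone, what a methoxy group or a nitrile would give at this aromatic carbon remains open. Also open, going by these compounds, is whether the step seen with trifluoromethyl would carry over to compounds with a 4-fluorobenzyl on the sulfur or another group in place of the bromine.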